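Lengthening the Butyl Chain on Compound 2

The source may report more compounds than this note shows. Statements on the series, on what has been measured and on what is new or still open speak of the compounds shown alone.

Measured compounds:
compound 1 `CCCCCNc1nc(NCCCCC)c2ccccc2n1` with 5250 nM
compound 2 `CCCCNc1nc(SCC)nc2ncccc12` with 20900 nM

Both compounds were tested in a functional assay on T-24 cells (Homo sapiens) for cytotoxicity, read by neutral red uptake, with a stated time of 72 h; on this read-out higher numbers stand for weaker inhibition and lower numbers for stronger inhibition. Compound 1 gives 5250 nM, while compound 2 gives 20900 nM. Of the two numbers, that of compound 2 is the higher one, and the gap to the lower number of compound 1 lies beyond the usual scatter. Within the data shown here, no step between these two structures is counted, as they differ in more than one place.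

Compound 3 `CCCCCCNc1nc(SCC)nc2ncccc12` is not yet measured in this assay. It differs from compound 2 in one place: ethyl in place of hydrogen on a saturated chain carbon, four bonds along the chain from a nitrogen on an aromatic ring. Among the measured compounds shown here, no measured pair shows this change, so the size of its step is open. A small step toward a lower number, or none beyond the scatter, is expected for compound 3, amounting to a 1.7-fold lower number from compound 2 to compound 3 (0.24 log units; within the scatter). Compound 3 is therefore estimated at 12000 nM, within a range from 4000 nM to 35000 nM.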

Compound 3, half-maximal inhibitory concentration: 5900 nM
For compound 3 the middle estimate is 2.0-fold (0.31 log units) above the measured one, within the range that was stated.
By their numbers in this assay, from the lowest: compounds 1 and 3 (each within the scatter of the next); then compound 2.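

Ethyl in place of hydrogen on a saturated chain carbon, four bonds along the chain from a nitrogen on an aromatic ring, gives a 3.5-fold lower number from compound 2 to compound 3 (0.55 log units; beyond the scatter) in this assay. Among these compounds, this is the first change in one place that can be read here, and it shows that this chain position is not indifferent to the change, since the step lies beyond the scatter. The two earlier compounds differ in more than one place, so they could say nothing about this position.

Going by these compounds, whether a longer chain, a branched chain, or a chain ending in an amine or a carboxylic acid would move the number further at this place stays open. A single step also gives no trend along the chain, and nothing at hand gives a reason for this one.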